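The source may hold more compounds than are shown below. What is called first, only, known or untested is meant among the compounds shown, and "the series" means these compounds.

Measured so far in a functional assay on HL-60 cells (Homo sapiens) for antiproliferative activity, with a stated time of 24 h; a lower number here means a stronger inhibitor, a higher number a weaker inhibitor:
compound 1 `NC(=O)c1c(NC(=O)c2ccccc2F)sc2c1CCN(Cc1c(Cl)cccc1Cl)C2` — 10300 nM
compound 2 `NC(=O)c1c(NC(=O)c2ccccc2F)sc2c1CCN(Cc1ccc(Cl)cc1Cl)C2` — 13100 nM

Going by the values given here, compound 2 gives the highest of the two numbers; its only neighbour is compound 1, and the step of a 1.3-fold higher number from compound 1 to compound 2 (0.10 log units; within the scatter) lies within the scatter, so the two stand together rather than apart. Next comes compound 3 `NC(=O)c1c(NC(=O)c2ccccc2F)sc2c1CCN(C(=S)Nc1ccccc1Cl)C2`, not yet measured in this assay. Relative to compound 2 the change is a group of 10 heavy atoms (7 carbon, 1 nitrogen, 1 sulfur, 1 chlorine; one six-membered aromatic ring of carbon only) in place of a group of 9 heavy atoms (7 carbon, 2 chlorine; one six-membered aromatic ring of carbon only), on an amine nitrogen in a ring. Among the compounds with values here, the single measured step, a 1.3-fold higher number from compound 1 to compound 2 (0.10 log units; within the scatter), exchanged one dichlorophenyl for another and left the kind of group on the ring nitrogen unchanged; the change to compound 3 replaces that whole group, so no measured step bears on it directly. With nothing comparable to lean on, no step beyond the scatter is expected in either direction, and the expected step is a 1.1-fold lower number from compound 2 to compound 3 (0.04 log units; within the scatter). Compound 3 is therefore estimated at 12000 nM, with a wide range from 3000 nM to 45000 nM reflecting the absence of a bearing step.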

Compound 3, half-maximal inhibitory concentration: 12500 nM
Compound 3: middle estimate off by 1.0-fold (0.02 log units), on the low side, and the stated range covers the measured number.
By their numbers in this assay, from the lowest: compounds 1, 3 and 2 (each within the scatter of the next).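

In this assay, putting the group with a double bond outside aromatic rings, a hydrogen-bond donor and a hydrogen-bond acceptor on the amine nitrogen in a ring gives a 1.0-fold lower number from compound 2 to compound 3 (0.02 log units; within the scatter) and a 1.2-fold higher number from compound 1 to compound 3 (0.08 log units; within the scatter). The position therefore shows no step beyond the scatter for replacing the whole dichlorobenzyl group, whereas the earlier pair covered only an exchange of one dichlorophenyl for another. No measurement on hand accounts for this result.

As far as these compounds go, all three groups on this nitrogen carry a six-membered aromatic ring of carbon only, so the effect of a carboxylic acid or a short alkyl chain there remains open. The rest of the shared core is the same in all three compounds, which leaves its contribution to the antiproliferative number unknown.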